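The source may report more compounds than this note shows. Statements on the series, on what has been measured and on what is new or still open speak of the compounds shown alone.

Measured compounds:
compound 1 `CN1CCN(c2ccc(NC(=N)c3cc4cn[nH]c4cn3)cc2)CC1`: 45400 nM
compound 2 `N=C(Nc1ccccc1)c1cc2cn[nH]c2cn1`: "not determined" (no result reported)

In a functional assay on PC-3 cells (Homo sapiens) for cytotoxicity, read by MTT assay, with a stated time of 72 h (a higher number here means a weaker inhibitor, a lower number a stronger inhibitor), compound 1 gives 45400 nM, a weak result. For compound 2, the shared core carrying a plain phenyl on the amidine, this assay reports only "not determined" (no result reported), so compound 2 stands on no number at all, and nothing can be said about how it compares with compound 1.

Compound 3 `COc1ccc(Cn2ncc3cc(C(=N)Nc4ccccc4)ncc32)cc1` differs from compound 2 by 4-methoxybenzyl in place of hydrogen on an aromatic nitrogen. Among the compounds with values here, no measured pair tells what such a change does, and since compound 2 itself is without a number, there is no anchor beyond the weak value of compound 1. On that footing compound 3 is expected to lie in a similarly weak region, with a wide band of uncertainty in either direction and a real chance that this assay returns only a limit. The estimated value for compound 3 is 30000 nM, within a range from 5000 nM to 100000 nM.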

Compound 3, half-maximal inhibitory concentration: 36000 nM
Beside the measured number, compound 3's estimate is 1.2-fold (0.08 log units) below it; low and high end bracket the measured number.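

In this assay, within the data shown here, compound 3 gives 36000 nM while compound 2 has no number, so no step between compound 2 and compound 3 can be read. From the compounds shown here alone, what 4-methoxybenzyl in place of hydrogen does to this value stays open. No evidence at hand bears on this result.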